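Methoxyphenyl in Place of Methylphenyl: Lipophilicity Outlook

The compounds below may be only part of what the source reports. "The series", "measured", "known", "first", "only" and "open" are said of these compounds alone.

Of the compounds shown here, two sharing one core have been measured in a physicochemical assay for lipophilicity, in phosphate buffer, measured as octanol-water partition; a higher number here means a more lipophilic compound, a lower number a more polar compound. Compound 1 `Cc1ccccc1NC(=S)NC(=O)Nc1ccc2c(c1)C(=O)C(=O)N2Cc1ccccc1Cl` gives 3.7. Compound 2 `Cc1ccc(NC(=S)NC(=O)Nc2ccc3c(c2)C(=O)C(=O)N3Cc2ccccc2Cl)cc1` gives 3.73 in this assay and thus sits alongside compound 1, since the step of a number 0.03 log units higher from compound 1 to compound 2 (within the scatter) lies within the scatter. Compound 3 `COc1ccccc1NC(=S)NC(=O)Nc1ccc2c(c1)C(=O)C(=O)N2Cc1ccccc1Cl` has not yet been measured. It differs from compound 2 in one place: 2-methoxyphenyl in place of 4-methylphenyl on an amide-type nitrogen. Within the data shown here, the single measured step bears on this only loosely. Among the measured compounds shown here, that step kept the methyl group and only changed where it sits on the ring, whereas the new change replaces that group with a methoxy group, for which no measured step exists. A methoxy group in place of a methyl group usually leaves a compound somewhat more polar, so compound 3 is expected to come out a little lower, by a number 0.33 log units lower from compound 2 to compound 3 (beyond the scatter), at an estimated 3.4 with a range from 3 to 3.8.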

Compound 3, partition coefficient: 3.18
Estimate against measurement, compound 3: 0.22 log units above; measured number inside the range.
By their numbers in this assay, from the lowest: compound 3; then compounds 1 and 2 (each within the scatter of the next).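

In this assay, among these compounds, the earlier pair showed only that the methyl group could sit in either of two places on this ring without leaving the scatter, whereas changing the group itself does move the number. Methoxy in place of methyl on an aromatic carbon gives a number 0.52 log units lower from compound 1 to compound 3 (beyond the scatter), and 2-methoxyphenyl in place of 4-methylphenyl on the amide-type nitrogen gives a step of similar size, a number 0.55 log units lower from compound 2 to compound 3 (beyond the scatter). The compounds shown contain nothing that accounts for this drop.

Whether a methoxy group would give the same number elsewhere on this ring remains open, since only the 2-methoxyphenyl compound is shown. Also open, on these data alone, is how other groups on this ring would read, such as an ethoxy group, an amine or a carboxylic acid.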